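The source may hold more compounds than are shown below. What is called first, only, known or untested is meant among the compounds shown, and "the series" means these compounds.

In a functional assay on B16 cells (Mus musculus) for cytotoxicity, read by CCK-8 assay, with a stated time of 24 h (on this read-out lower numbers stand for stronger inhibition and higher numbers for weaker inhibition), compound 1 `COc1ccccc1Oc1c(N)nc(-c2cccc(C)c2)nc1Cl` gives 13100 nM, compound 2 `COc1cccc(-c2nc(N)c(Oc3ccccc3OC)c(Cl)n2)c1` gives 23600 nM, and compound 3 `COc1ccccc1Oc1c(N)nc(-c2ccc(F)cc2)nc1Cl` gives 2990 nM, the lowest of the three numbers. The next compound is compound 4 `COc1ccccc1Oc1c(N)nc(-c2cccc(Cl)c2)nc1Cl`, which differs from compound 3 as follows: 3-chlorophenyl in place of 4-fluorophenyl on an aromatic carbon. This places 3-chlorophenyl where 4-fluorophenyl stood, on an aromatic carbon between two ring nitrogen atoms.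

Within the data shown here, two measured steps bear most directly on this change. Going to 4-fluorophenyl from 3-methylphenyl gave a 4.4-fold lower number from compound 1 to compound 3 (0.64 log units; beyond the scatter), and going to it from 3-methoxyphenyl gave a 7.9-fold lower number from compound 2 to compound 3 (0.90 log units; beyond the scatter). Exchanging those two groups for each other gave only a 1.8-fold higher number from compound 1 to compound 2 (0.26 log units; within the scatter). Among the measured compounds shown here, no measured compound yet carries 3-chlorophenyl, so the expectation rests on compound 1 and compound 2 as the nearest analogues, and the change to compound 4 runs opposite to their steps to compound 3. A rise of modest size is therefore expected in this assay, an estimated 3.3-fold higher number from compound 3 to compound 4 (0.52 log units; beyond the scatter). Compound 4 is estimated at 10000 nM, with an expected range of 4000 nM to 24000 nM.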

Compound 4, half-maximal inhibitory concentration: 17900 nM
Estimate against measurement, compound 4: 1.8-fold (0.25 log units) below; the measured number falls inside the stated range.
By their numbers in this assay, from the lowest: compound 3; then compounds 1, 4 and 2 (each within the scatter of the next).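

In this assay, the change carries a 6.0-fold higher number from compound 3 to compound 4 (0.78 log units; beyond the scatter), so compound 3, with its 4-fluorophenyl group, stays alone at the low end of the series. The new chloro group also does not separate from the other two groups on the same ring position, with a 1.4-fold higher number from compound 1 to compound 4 (0.14 log units; within the scatter) and a 1.3-fold lower number from compound 2 to compound 4 (0.12 log units; within the scatter), so 3-chlorophenyl, 3-methylphenyl and 3-methoxyphenyl all sit together, well away from 4-fluorophenyl. No independent measurement bears on what lies behind this gap.

Compound 3 and compound 4 differ in both the halogen and its place on the ring, so the compounds shown cannot say which of the two matters. A 4-chlorophenyl or 3-fluorophenyl group would pull these apart, and an unsubstituted phenyl group would give a reference for both.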